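Swapping a Methoxy Group for Hydrogen

This account rests on a few compounds, and the source may have more. Where it says the series, first, only, none or still open, it means among the compounds named here.

Compound 1 (`CN(C)C(=O)c1cccc(S(=O)(=O)N2CSC[C@H]2C(=O)O[C@@H](Cc2c(Cl)c[n+]([O-])cc2Cl)c2ccc(OC(F)F)c(OCC3CC3)c2)c1`) gives 94%
Compound 2 (`COc1ccc(S(=O)(=O)N2CCC[C@H]2C(=O)O[C@@H](Cc2c(Cl)c[n+]([O-])cc2Cl)c2ccc(OC(F)F)c(OCC3CC3)c2)cc1C(=O)N(C)C`) gives 101%
Compound 3 (`COc1ccc(S(=O)(=O)N2CCCC[C@H]2C(=O)O[C@@H](Cc2c(Cl)c[n+]([O-])cc2Cl)c2ccc(OC(F)F)c(OCC3CC3)c2)cc1C(=O)N(C)C`) gives 88.2%

In an ADME assay on a cell-free system (plasma, Homo sapiens) for metabolic stability, read by LC-MS, using NADPH, with a stated time of 60 min, tested at 1 uM (a lower number here means that less of the compound is left, a higher number that more of the compound is left), compound 3 gives 88.2%, which is within the scatter of compound 1 but beyond the scatter below compound 2. Compound 4 (`CN(C)C(=O)c1cccc(S(=O)(=O)N2CCCC[C@H]2C(=O)O[C@@H](Cc2c(Cl)c[n+]([O-])cc2Cl)c2ccc(OC(F)F)c(OCC3CC3)c2)c1`) has hydrogen in place of methoxy on an aromatic carbon, ortho to a dimethylcarbamoyl group (hydrogen in place of methoxy on an aromatic carbon). Going by the values given here, no measured pair shows this change alone. Compound 1 also has no methoxy group, though it differs elsewhere too, and gives 94% in this assay, so no step beyond the scatter is expected. The estimate is a number 4.8 percentage points higher from compound 3 to compound 4 (within the scatter), an upward step of a size within the scatter. Compound 4 has an estimated value of 93%, ranging from 82% to 104% by this estimate.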

Compound 4, percent of the compound remaining: 105%
Compound 4: middle estimate off by 12 percentage points, on the low side; measured number outside the range, above it.
By their numbers in this assay, from the lowest: compounds 3, 1, 2 and 4 (each within the scatter of the next, the first and the last beyond it).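

In this assay, hydrogen in place of methoxy gives a number 16.8 percentage points higher from compound 3 to compound 4 (beyond the scatter). Going by these compounds alone, this is the first pair differing in this one place, and it shows that the aromatic carbon ortho to a dimethylcarbamoyl group is a place where a single small change can shift how much compound is left, with more remaining when hydrogen stands there. Nothing available explains this step. The compounds shown leave open whether the same change gives a similar step on another core, and how an amine, a fluorine atom or a carboxylic acid at this place would compare.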